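Triazole-linked oxime ethers on a triterpenoid core: cytotoxicity notes

The source may hold more compounds than are shown below. What is called first, only, known or untested is meant among the compounds shown, and "the series" means these compounds.

Measured in a functional assay on HepG2 cells (Homo sapiens) for cytotoxicity, read by MTT assay, with a stated time of 48 h; on this read-out lower numbers stand for stronger inhibition and higher numbers for weaker inhibition:
compound 1 `CC(C)=CCC/C(C)=C/CC/C(C)=C/CC[C@@H]1[C@@]2(C)CC/C(=N\OCc3cn(-c4ccccc4)nn3)C(C)(C)[C@@H]2CC[C@@]1(C)O`: 9520 nM
compound 2 `CC(C)=CCC/C(C)=C/CC/C(C)=C/CC[C@@H]1[C@@]2(C)CC/C(=N\OCc3cn(-c4ccc(F)c(Cl)c4)nn3)C(C)(C)[C@@H]2CC[C@@]1(C)O`: 58900 nM

Among the compounds with values here, compound 1 holds the lowest of the two numbers recorded so far, with compound 2 the only neighbour. Within the data shown here, the single measured step is a 6.2-fold higher number from compound 1 to compound 2 (0.79 log units; beyond the scatter), a modest move toward weaker inhibition when 3-chloro-4-fluorophenyl stands in place of phenyl on the aromatic nitrogen.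

Compound 3 `COc1cc(OC)c(-n2cc(CO/N=C3\CC[C@]4(C)[C@@H](CC/C=C(\C)CC/C=C(\C)CCC=C(C)C)[C@](C)(O)CC[C@H]4C3(C)C)nn2)c(OC)c1` differs from compound 1 in one place: 2,4,6-trimethoxyphenyl in place of phenyl on an aromatic nitrogen. Among the measured compounds shown here, the change sits at the same ring nitrogen that the measured step altered, so a 6.2-fold higher number from compound 1 to compound 2 (0.79 log units; beyond the scatter) is the only guide, and it points to a higher number. The entering group here is not the same as in compound 2, so the size of the step carries more uncertainty than its direction.

Compound 3 is therefore expected to give 30000 nM, within a range of 10000 nM to 90000 nM. The step implied by this estimate is a 3.2-fold higher number from compound 1 to compound 3 (0.50 log units; beyond the scatter).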

Compound 3, half-maximal inhibitory concentration: 14100 nM
Estimate against measurement, compound 3: 2.1-fold (0.33 log units) above; the range from low to high includes it.
By their numbers in this assay, from the lowest: compounds 1 and 3 (each within the scatter of the next); then compound 2.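

In this assay, the step of a 1.5-fold higher number from compound 1 to compound 3 (0.17 log units; within the scatter) shows that the aromatic nitrogen of the triazole can carry a much larger aryl group, 2,4,6-trimethoxyphenyl with 12 heavy atoms and 3 hydrogen-bond acceptors against 6 heavy atoms and none for phenyl, without a change beyond the scatter, so the weaker number of compound 2 does not extend to every substituted phenyl at this position. The step of a 4.2-fold lower number from compound 2 to compound 3 (0.62 log units; beyond the scatter) adds that the identity of the aryl substituents matters here, with compound 2 standing apart from the other two compounds in the series. Nothing available bears on the reason for this difference between the two substituted rings.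

Still open, as far as these compounds go, is whether the chlorine, the fluorine or the pair accounts for the number of compound 2, and whether a single methoxy group reads like the three in compound 3. From the compounds shown here alone, how an amine or a carboxylic acid on the phenyl ring would read in this assay also remains unknown, so the limits of what this position accepts are not yet defined.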